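A Longer Chain on the Dimethylamino Compound

This account rests on a few compounds, and the source may have more. Where it says the series, first, only, none or still open, it means among the compounds named here.

Compound 1 `CCCCCCCCC(CCO)n1cnc2c(Cl)ncnc21` gives 1650 nM
Compound 2 `CCCCCCCCC(CCO)n1cnc2c(N(C)C)ncnc21` gives 19800 nM
Compound 3 `CCCCCCCCC(CCO)n1cnc2c(N)ncnc21` gives 11600 nM

In a functional assay on HCT-116 cells (Homo sapiens) for antiproliferative activity, read by MTT assay, with a stated time of 48 h (on this read-out lower numbers stand for stronger inhibition and higher numbers for weaker inhibition), compound 2 stands at the weak end of this small set, with 19800 nM as its value. The step to its nearest neighbour is a 1.7-fold lower number from compound 2 to compound 3 (0.23 log units; within the scatter) and gives no real separation. The largest step in the set is a 12-fold higher number from compound 1 to compound 2 (1.08 log units; beyond the scatter) and marks a clear gap.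

Compound 4 `CCCCCCCCCCC(CCO)n1cnc2c(N(C)C)ncnc21` keeps the dimethylamino group of compound 2 and alters only the chain. The change is ethyl in place of hydrogen on a saturated chain carbon, nine bonds along the chain from an aromatic nitrogen and nothing else differs.

Among the compounds with values here, none of the measured steps touches that chain. The step of a 7.0-fold higher number from compound 1 to compound 3 (0.85 log units; beyond the scatter) and the two above all exchange the group on an aromatic carbon, so they say nothing direct about a longer chain. With no measured guide to size or direction, the best starting point is compound 2 itself at 19800 nM and no shift beyond the scatter is expected. The expected step is a 1.2-fold lower number from compound 2 to compound 4 (0.09 log units; within the scatter) and this estimate is a cautious one. In this assay the expected value for compound 4 is 16000 nM within an estimated range of 6000 nM to 40000 nM.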

Compound 4, half-maximal inhibitory concentration: 5490 nM
Compound 4: middle estimate off by 2.9-fold (0.46 log units), on the high side; the measured number lies below the stated range.
By their numbers in this assay, from the lowest: compound 1; then compound 4; then compounds 3 and 2 (each within the scatter of the next).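

Every earlier step exchanged the group on an aromatic carbon, so the chain had not yet been tested. In this assay, ethyl in place of hydrogen on a saturated chain carbon, nine bonds along the chain from an aromatic nitrogen, gives a 3.6-fold lower number from compound 2 to compound 4 (0.56 log units; beyond the scatter), which shows that with the dimethylamino group held fixed, this far part of the chain still affects the read-out, and that the longer chain goes with stronger inhibition. Nothing measured here explains why the number moves.

This is a single change on a single compound, so it does not show whether the trend would continue with a still longer chain or reverse, or whether a branched chain, or a chain ending in an amine or a carboxylic acid, would behave in the same way. It also leaves open whether the same ethyl extension would give a step of similar size on compound 1, which carries chloro, or on compound 3, which carries amino, since the chain and the group on the aromatic carbon might not act independently.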